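Benzimidazole to Benzoxazolone on the Amide Side Chain

The source may hold more compounds than are shown below. What is called first, only, known or untested is meant among the compounds shown, and "the series" means these compounds.

In an assay on blood for inhibition of C-X-C chemokine receptor type 3 (Homo sapiens), with a stated time of 30 min (on this read-out higher numbers stand for weaker inhibition and lower numbers for stronger inhibition), compound 2 `CCOc1ncc(-c2nc(C(F)(F)F)sc2N2CCN(C(=O)Cn3cnc4ccccc43)[C@H](C)C2)cn1` gives 192 nM, the lower of the two numbers in hand. Compound 1 `Cc1nc(-c2nc3ccccc3[nH]2)c(N2CCN(C(=O)Cn3cnc4cccnc43)[C@H](C)C2)s1` gives 1060 nM in this assay, a number that lies beyond the scatter above that of compound 2; the two compounds differ in more than one place, so their gap is not traced to any single change. Compound 3 `CCOc1ncc(-c2nc(C(F)(F)F)sc2N2CCN(C(=O)Cn3c(=O)oc4ccccc43)[C@H](C)C2)cn1` is not yet measured. It differs from compound 2 by a group of 10 heavy atoms (7 carbon, 1 nitrogen, 2 oxygen; one five-membered aromatic ring with 2 hetero atoms, one six-membered aromatic ring of carbon only) in place of a group of 9 heavy atoms (7 carbon, 2 nitrogen; one five-membered aromatic ring with 2 hetero atoms, one six-membered aromatic ring of carbon only), on a saturated chain carbon bound to a carbonyl carbon. Among the measured compounds shown here, no measured pair shows this exchange, so the expected size of the step rests on the change itself: both the leaving and the entering group hold one five-membered aromatic ring with 2 hetero atoms and one six-membered aromatic ring of carbon only, and the expectation is a step of modest size, leaning toward a higher number. For compound 3 the estimate in this assay is 350 nM, within 100 nM to 1200 nM, which means an expected step of a 1.8-fold higher number from compound 2 to compound 3 (0.26 log units; within the scatter).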

Compound 3, half-maximal inhibitory concentration: 536 nM
Beside the measured number, compound 3's estimate is 1.5-fold (0.19 log units) below it; the range from low to high includes it.
By their numbers in this assay, from the lowest: compound 2; then compounds 3 and 1 (each within the scatter of the next).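

Read in this assay, exchanging the 1H-benzimidazol-1-yl group for the benzoxazolone on a saturated chain carbon bound to a carbonyl carbon gives a 2.8-fold higher number from compound 2 to compound 3 (0.45 log units; beyond the scatter), the first reading of a change made in one place only. The position therefore responds to this exchange beyond the scatter, even though both groups hold one five-membered aromatic ring with 2 hetero atoms and one six-membered aromatic ring of carbon only, and the 1H-benzimidazol-1-yl group gives the lower number of the two. Nothing in hand accounts for the size or direction of this step.

The compounds shown leave open whether the same exchange would give a similar step on the core of compound 1, which differs from compound 2 in more than one place. They also leave open how a simple amine or a carboxylic acid would read on this chain carbon in place of either two-ring group.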